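This account rests on a few compounds, and the source may have more. Where it says the series, first, only, none or still open, it means among the compounds named here.

Measured in a functional assay on microsomes from liver (Rattus norvegicus, strain Wistar) for inhibition, with a stated time of 15 min; on this read-out lower numbers stand for stronger inhibition and higher numbers for weaker inhibition:

compound 1, `COc1cc(C2CC(c3cc4ccccc4o3)=NN2C(=O)Nc2ccc(F)cc2)ccc1O`, 125000000 nM
compound 2, `COc1cc(C2CC(c3cc4ccccc4o3)=NN2C(=O)Nc2ccccc2O)ccc1O`, 22000000 nM
compound 3, `COc1ccc(NC(=O)N2N=C(c3cc4ccccc4o3)CC2c2ccc(O)c(OC)c2)cc1`, 29000000 nM

The three compounds share one core and differ only in the aryl group carried on the amide-type nitrogen. Compound 3 stands second highest of the three numbers: its nearest neighbour is compound 2, with a 1.3-fold higher number from compound 2 to compound 3 (0.12 log units; within the scatter), and its furthest is compound 1, with a 4.3-fold lower number from compound 1 to compound 3 (0.63 log units; beyond the scatter). The other measured step is a 5.7-fold lower number from compound 1 to compound 2 (0.75 log units; beyond the scatter).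

Compound 4, `COc1cc(C2CC(c3cc4ccccc4o3)=NN2C(=O)Nc2ccc(Cl)cc2)ccc1O`, is the next compound to be measured. Its difference from compound 3 is chloro in place of methoxy on an aromatic carbon.

Within the data shown here, only one measured step touches the same position: from compound 1 to compound 3, where methoxy replaced fluoro and the number fell, with a 4.3-fold lower number from compound 1 to compound 3 (0.63 log units; beyond the scatter). Among the measured compounds shown here, compound 4 now carries a halogen at that position again, so the expectation is that the number moves back up, toward that of compound 1, although no measured compound shows how chloro compares with fluoro there. The step from compound 3 to compound 4 in this assay is therefore expected to be a modest rise, a 2.4-fold higher number from compound 3 to compound 4 (0.38 log units; beyond the scatter).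

On that basis compound 4 is estimated to give 70000000 nM in this assay, within a range from 25000000 nM to 200000000 nM.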

Compound 4, half-maximal inhibitory concentration: 121000000 nM
The estimate for compound 4 lay 1.7-fold (0.24 log units) below the measured number, within the range that was stated.
By their numbers in this assay, from the lowest: compounds 2 and 3 (each within the scatter of the next); then compounds 4 and 1 (each within the scatter of the next).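

In this assay, among these compounds, the 4-chlorophenyl group cannot be told apart from the 4-fluorophenyl group (a 1.0-fold lower number from compound 1 to compound 4 (0.01 log units; within the scatter)), a comparison between two halogens at this place that no earlier compound allowed. The change from 4-methoxyphenyl to 4-chlorophenyl (a 4.2-fold higher number from compound 3 to compound 4 (0.62 log units; beyond the scatter)) runs opposite to the earlier change from fluoro to methoxy (a 4.3-fold lower number from compound 1 to compound 3 (0.63 log units; beyond the scatter)), so the number moves in one direction when methoxy enters and in the other when a halogen returns. The chloro compound also differs clearly from the 2-hydroxyphenyl compound (a 5.5-fold higher number from compound 2 to compound 4 (0.74 log units; beyond the scatter)), and among these four compounds the two halogen-bearing members, compound 1 and compound 4, therefore form one group with the higher numbers, while compound 2 and compound 3 form another with the lower numbers.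

From the compounds shown here alone, it remains open whether bromo would stay with the two halogen-bearing compounds, and whether an amine or a carboxylic acid at this place would fall with them or with the methoxy compound. Nothing measured alongside these numbers speaks to what lies behind the steps.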